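Amino for Dimethylamino on the Longer-Chain Compound

The compounds below may be only part of what the source reports. "The series", "measured", "known", "first", "only" and "open" are said of these compounds alone.

Compound 1 `CCCCCCCC(CCO)n1cnc2c(N(C)C)ncnc21` and compound 2 `CCCCCCCC(CCO)n1cnc2c(N)ncnc21` share a core and differ by amino in place of dimethylamino on an aromatic carbon. In a functional assay on SW480 cells (Homo sapiens) for antiproliferative activity, read by MTT assay, with a stated time of 48 h (on this read-out lower numbers stand for stronger inhibition and higher numbers for weaker inhibition), compound 1 reaches only the limit of the assay, > 50000 nM. Compound 2 likewise gives only a limit in this assay, > 50000 nM. Together they leave a step that the two limits leave unreadable from compound 1 to compound 2. Compound 3 `CCCCCCCCCCCC(CCO)n1cnc2c(N(C)C)ncnc21` differs from compound 1 by butyl in place of hydrogen on a saturated chain carbon, eight bonds along the chain from an aromatic nitrogen; in this assay compound 3 gives 11800 nM, which is an at least 4.2-fold lower number from compound 1 to compound 3 (0.62 log units; beyond the scatter). Compound 4 `CCCCCCCCCCCC(CCO)n1cnc2c(N)ncnc21` is not yet measured and differs from compound 3 by amino in place of dimethylamino on an aromatic carbon, the same change as from compound 1 to compound 2. That earlier step sits at the limit of > 50000 nM in this assay, at which 2 of the 3 values shown sit, on both sides, so its size cannot be read. The expected step of a 1.3-fold higher number from compound 3 to compound 4 (0.10 log units; within the scatter) therefore rests only on compound 3 and its value 11800 nM, and is estimated as small. Compound 4 is expected to give about 15000 nM, somewhere between 5000 nM and 50000 nM.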

Compound 4, half-maximal inhibitory concentration: 11600 nM
Compound 4: middle estimate off by 1.3-fold (0.11 log units), on the high side; the measured number falls inside the stated range.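

On the core of compound 3, amino in place of dimethylamino gives a 1.0-fold lower number from compound 3 to compound 4 (0.01 log units; within the scatter) in this assay. Butyl in place of hydrogen on the saturated chain carbon gives an at least 4.3-fold lower number from compound 2 to compound 4 (0.63 log units; beyond the scatter), and it lowers the number on both the dimethylamino and amino cores, though its exact size stays unknown on either: the same change on two cores in this assay, an at least 4.2-fold lower number (0.62 log units; beyond the scatter) from compound 1 to compound 3 and an at least 4.3-fold lower number (0.63 log units; beyond the scatter) from compound 2 to compound 4; the limit leaves it open whether they differ The amino change cannot be compared across cores, as its step on the core of compound 1 cannot be read, so nothing shows whether it carries over: the limit of > 50000 nM in this assay, at which 2 of the 4 values shown sit.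

The compounds shown leave open how a chain longer than that of compound 3 would behave. They also leave open whether a methylamino group on the same aromatic carbon would fit with amino and dimethylamino.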